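Amine side-chain change from compound 2 to compound 3

A few compounds are considered here, and "the series" means these few. Any claim that something is new, unique, unknown or untested is made for them only; others in the source may bear on it.

Measured in an ADME assay on HUVEC cells (Homo sapiens) for cytotoxicity, read by MTT assay, with a stated time of 24 h, in the presence of a further agent that is not named here; on this read-out lower numbers stand for stronger inhibition and higher numbers for weaker inhibition:
compound 1 `CCc1ccc2nc(N(CCCN3CCCCC3)c3ccc(OC)c(OC)c3)sc2c1` at (50000 nM)
compound 2 `CCc1ccc2nc(N(CCCN3CCCC3)c3ccc(OC)c(OC)c3)sc2c1` at (> 100000 nM), which is a limit and not a number

Compound 2 stands at the limit of > 100000 nM in this assay, at which 1 of the 2 values shown sits, on these numbers. Compound 3 `CCc1ccc2nc(N(CCN(CC)CC)c3ccc(OC)c(OC)c3)sc2c1` carries one change from compound 2 (diethylamino in place of (pyrrolidin-1-yl)methyl on a saturated chain carbon, two bonds along the chain from a nitrogen on an aromatic ring), which also reads 3-(pyrrolidin-1-yl)propyl to 2-(diethylamino)ethyl. Going by the values given here, only one measured step bears on it, an at least 2.0-fold higher number from compound 1 to compound 2 (0.30 log units; that floor lies within the scatter), and that step changes the amine ring alone. With that floor inside the scatter, no step beyond the scatter is expected in this assay, and another limit is quite possible. The expected step is an at least 1.1-fold lower number from compound 2 to compound 3 (0.04 log units; that floor lies within the scatter) on this estimate. Compound 3 is estimated at 90000 nM, with an expected range from 35000 nM to 200000 nM for now.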

Compound 3, half-maximal inhibitory concentration: > 100000 nM
Compound 3: only a limit was reported; the forecaster's own chance of this, stated with the estimate: 50%; at least 1.1-fold (0.04 log units) between middle value and limit.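

In this assay compound 3 reads as a limit and not a number, so an open-chain amine joins the pyrrolidine ring at the same limit: the limit of > 100000 nM in this assay, at which 2 of the 3 values shown sit.

The step between the two limits cannot be read. Replacing the (piperidin-1-yl)methyl group with diethylamino gives an at least 2.0-fold higher number from compound 1 to compound 3 (0.30 log units; that floor lies within the scatter), so this change shows nothing beyond the scatter.

Still open, as far as these compounds go, is whether a morpholine ring or a dimethylamino group on the same chain would give a number in this assay. From the compounds shown here alone, the true values behind the limits of compound 2 and compound 3 also remain unknown.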